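Nitrile replacement at the aryl terminus of compound 2

The compounds below may be only part of what the source reports. "The series", "measured", "known", "first", "only" and "open" are said of these compounds alone.

Three compounds of the series have numbers in a functional assay on mitochondria from heart for inhibition of peroxisomal acyl-coenzyme A oxidase 1 (Rattus norvegicus); on this read-out higher numbers stand for weaker inhibition and lower numbers for stronger inhibition. Among the compounds with values here, compound 1 `Cc1nc2cc(OC[C@H](O)CN3CCN(Cc4noc(-c5ccc(Cl)cc5)n4)CC3)ccc2s1` gives 2270 nM and compound 2 `Cc1nc2cc(OC[C@H](O)CN3CCN(Cc4noc(-c5ccc(C(F)(F)F)cc5)n4)CC3)ccc2s1` gives 380 nM, the lowest number of the three; the single change from chloro to trifluoromethyl on an aromatic carbon reads a 6.0-fold lower number from compound 1 to compound 2 (0.78 log units; beyond the scatter). Compound 3 `Cc1nc2cc(OC[C@H](O)CN3CCN(Cc4nc(-c5ccc(C(C)C)cc5)no4)CC3)ccc2s1` differs from compound 2 in more than one place. Compound 3 gives 1230 nM, a higher number than compound 2.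

Compound 4 `Cc1nc2cc(OC[C@H](O)CN3CCN(Cc4noc(-c5ccc(C#N)cc5)n4)CC3)ccc2s1` carries cyano in place of trifluoromethyl on an aromatic carbon. Within the data shown here, the only measured step that bears on it is the one from compound 1 to compound 2, which shows that the group on this aromatic carbon moves the number by a modest but clear amount. Among the measured compounds shown here, no compound with cyano at this place has been measured, so the direction rests on the observation that trifluoromethyl gave the lowest number so far and any other group tried here gave a higher one. A step of modest size toward a higher number, a 2.4-fold higher number from compound 2 to compound 4 (0.37 log units; beyond the scatter), is therefore expected, with a wide margin. The expected value for compound 4 in this assay is 900 nM, in the range 300 nM to 3000 nM.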

Compound 4, half-maximal inhibitory concentration: 4410 nM
The estimate for compound 4 lay 4.9-fold (0.69 log units) below the measured number; the measured number lies above the stated range.
By their numbers in this assay, from the lowest: compound 2; then compounds 3, 1 and 4 (each within the scatter of the next, the first and the last beyond it).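

In this assay, within the data shown here, the group on this aromatic carbon matters more than the earlier compounds showed: cyano in place of trifluoromethyl is a large loss, a 12-fold higher number from compound 2 to compound 4 (1.06 log units; beyond the scatter). Cyano and chloro cannot be told apart here, a 1.9-fold higher number from compound 1 to compound 4 (0.29 log units; within the scatter), so among the three groups at this place, only trifluoromethyl stands clear of the other two. No measurement on hand accounts for this separation.

Open, from the compounds shown here alone, is whether the low number of compound 2 is particular to trifluoromethyl or is shared by other groups at this place, such as trifluoromethoxy or tert-butyl. Also open, going by these compounds, is whether cyano in place of trifluoromethyl gives a step of this size on the core of compound 3.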